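Swapping an iodophenyl amine for a benzyl amine

The compounds below may be only part of what the source reports. "The series", "measured", "known", "first", "only" and "open" are said of these compounds alone.

Of the compounds shown here, three sharing one core have been measured in a functional assay on U2OS cells (Homo sapiens) for antiproliferative activity, read by MTT assay, with a stated time of 72 h; a lower number here means a stronger inhibitor, a higher number a weaker inhibitor. Compound 1 `CCCCCOC1=C(C(=O)c2ccccc2)C(c2ccc(Br)cc2)N(CCCn2ccnc2)C1=O` gives 9140 nM, compound 2 `O=C(C1=C(Nc2ccc(F)cc2)C(=O)N(CCCn2ccnc2)C1c1ccc(Br)cc1)c1ccccc1` gives 30000 nM, and compound 3 `O=C(C1=C(Nc2ccc(I)cc2)C(=O)N(CCCn2ccnc2)C1c1ccc(Br)cc1)c1ccccc1` gives 12000 nM. Compound 3 sits close to compound 1, the step of a 1.3-fold higher number from compound 1 to compound 3 (0.12 log units; within the scatter) lying within the scatter, while against compound 2 it shows a 2.5-fold lower number from compound 2 to compound 3 (0.40 log units; beyond the scatter). Compound 4 `O=C(C1=C(NCc2ccccc2)C(=O)N(CCCn2ccnc2)C1c1ccc(Br)cc1)c1ccccc1` differs from compound 3 by benzyl in place of 4-iodophenyl on an amine nitrogen. Among the compounds with values here, no measured step replaces the aryl group itself with a benzyl group, so the only guide is that changes at this amine have so far moved this assay only modestly. Compound 4 is therefore expected to show a small step of a 1.3-fold higher number from compound 3 to compound 4 (0.10 log units; within the scatter) in this assay, with an estimated value of 15000 nM and a range from 6000 nM to 40000 nM.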

Compound 4, half-maximal inhibitory concentration: 32500 nM
The estimate for compound 4 lay 2.2-fold (0.34 log units) below the measured number, and the stated range covers the measured number.
By their numbers in this assay, from the lowest: compounds 1 and 3 (each within the scatter of the next); then compounds 2 and 4 (each within the scatter of the next).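

In this assay, benzyl on the amine nitrogen gives a weaker result than 4-iodophenyl (a 2.7-fold higher number from compound 3 to compound 4 (0.43 log units; beyond the scatter)) but cannot be told apart from 4-fluorophenyl (a 1.1-fold higher number from compound 2 to compound 4 (0.03 log units; within the scatter)). Benzylamino also falls short of pentyloxy on the double-bonded ring carbon (a 3.6-fold higher number from compound 1 to compound 4 (0.55 log units; beyond the scatter)), so among the amines only the (4-iodophenyl)amino group stays within the scatter of pentyloxy. Nothing available here explains these differences. On these data alone, it remains open whether a benzyl group carrying iodo on its ring would track compound 3 or compound 4. A plain butyl chain on the same nitrogen is equally uncharted.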